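The source may hold more compounds than are shown below. What is called first, only, known or untested is meant among the compounds shown, and "the series" means these compounds.

Values in an ADME assay on MT4 cells (Homo sapiens) for cytotoxicity, read by MTT assay, with a stated time of 96 h (on this read-out higher numbers stand for lower toxicity in this test and lower numbers for higher toxicity in this test), so far
- compound 1 `CCc1c(C(F)c2cc(C)cc(C)c2)[nH]c(=O)n(COCc2ccc(I)cc2)c1=O` gives > 100000 nM (a limit, not a number)
- compound 2 `CCc1c(C(F)c2cc(C)cc(C)c2)n(COCc2ccc(C#CC=O)cc2)c(=O)[nH]c1=O` gives 27000 nM
- compound 3 `CCOCn1c(C(F)c2cc(C)cc(C)c2)c(CC)c(=O)[nH]c1=O` gives 85000 nM

Compound 3 at 85000 nM holds the higher of the two true numbers in the series. Among the measured compounds shown here, compound 1 at > 100000 nM stands only as a limit of the assay and yields no step.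

The next change leads to compound 4 `CCc1c(C(F)c2cc(C)cc(C)c2)n(COCc2ccc(I)cc2)c(=O)[nH]c1=O` and is counted as 4-iodophenyl in place of methyl on a saturated chain carbon bound to an oxygen on a saturated carbon in the sense of 4-iodophenyl in place of methyl on a saturated chain carbon bound to an oxygen on a saturated carbon.

For the measured compounds named here, one measured step bears on this change. It is a 3.1-fold higher number from compound 2 to compound 3 (0.50 log units; beyond the scatter) and comes from methyl replacing 4-(2-formylethynyl)phenyl at that same place. It is modest but beyond the scatter.

Compound 4 takes the reverse kind of change, with a substituted phenyl entering where methyl leaves. On the evidence of a 3.1-fold higher number from compound 2 to compound 3 (0.50 log units; beyond the scatter) alone a lower number is expected in this assay by a similar modest amount. The expected step is a 2.8-fold lower number from compound 3 to compound 4 (0.45 log units; beyond the scatter) and rests on that single precedent. For compound 4 the estimated value is 30000 nM with an expected range from 11000 nM to 85000 nM and some expected chance of only a limit.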

Compound 4, half-maximal cytotoxic concentration: 43000 nM
Compound 4: the middle estimate sits 1.4-fold (0.16 log units) below what was measured; the measured number falls inside the stated range.
By their numbers in this assay, from the lowest: compounds 2, 4 and 3 (each within the scatter of the next, the first and the last beyond it). At a limit, above all of these: compound 1.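

In this assay, 4-iodophenyl in place of methyl on a saturated chain carbon bound to an oxygen on a saturated carbon gives a 2.0-fold lower number from compound 3 to compound 4 (0.30 log units; within the scatter), so a group of seven heavy atoms with a six-membered aromatic ring can replace a single carbon here without a change beyond the scatter. Iodo in place of 2-formylethynyl on an aromatic carbon gives a 1.6-fold higher number from compound 2 to compound 4 (0.20 log units; within the scatter); of the three steps now available, only a 3.1-fold higher number from compound 2 to compound 3 (0.50 log units; beyond the scatter) lies beyond the scatter, so the contrast between methyl and a substituted phenyl seen earlier does not hold for the 4-iodophenyl group in this assay. Compound 1, which also carries the ((4-iodobenzyl)oxy)methyl group, remains a limit and gives no step: the limit of > 100000 nM in this assay, at which 1 of the 4 values shown sits.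

With only methyl and two substituted phenyl groups at this place, the series leaves open whether a longer chain in place of methyl would shift the number in this assay beyond the scatter. It also leaves open whether an amine or a carboxylic acid on the phenyl ring would do so.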